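Bromo to nitro at the meta position: compound 3

The source may report more compounds than this note shows. Statements on the series, on what has been measured and on what is new or still open speak of the compounds shown alone.

Measured so far in a functional assay on CHO cells for agonist activity at adenosine receptor A1 (Homo sapiens), read by fluorescence and ERK phosphorylation, with stated times of 30 min and 1.5 h, tested at 10 uM; a higher number here means a stronger effect of the compound at the concentration tested, a lower number a weaker effect:
compound 1 `Nc1scc(-c2ccccc2)c1C(=O)c1ccccc1` gives 48%
compound 2 `Nc1scc(-c2cccc(Br)c2)c1C(=O)c1ccccc1` gives 76%

Compound 2 stands highest of the two numbers in this assay, with compound 1 the nearest. Going by the values given here, the single measured step, a number 28 percentage points higher from compound 1 to compound 2 (beyond the scatter), is modest and beyond the scatter.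

Compound 3 `Nc1scc(-c2cccc([N+](=O)[O-])c2)c1C(=O)c1ccccc1` differs from compound 2 as follows: nitro in place of bromo on an aromatic carbon. Among the compounds with values here, no measured step bears directly on a nitro group; the only step available concerns the same place, yet another group. A step within the scatter is therefore expected, a number 11 percentage points lower from compound 2 to compound 3 (beyond the scatter), with wide uncertainty. For compound 3 the estimate in this assay is 65%, between 40% and 88%.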

Compound 3, a percentage reported as activity, at one concentration (the size of the read-out at that concentration, not a potency): 50%
Estimate against measurement, compound 3: 15 percentage points above; the measured number falls inside the stated range.
By their numbers in this assay, from the lowest: compounds 1 and 3 (each within the scatter of the next); then compound 2.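

In this assay, the rise seen with bromo at this position does not carry over to nitro, with a number 26 percentage points lower from compound 2 to compound 3 (beyond the scatter). Against hydrogen at the same carbon, nitro gives no readable change, with a number 2 percentage points higher from compound 1 to compound 3 (within the scatter), so among these three compounds, substitution here does not by itself raise the number. Nothing available accounts for the difference between bromo and nitro.

From the compounds shown here alone, whether a smaller halogen such as chloro would keep the effect of bromo remains open. So does whether an amine or a carboxylic acid at this carbon would track bromo or nitro.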